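The source may hold more compounds than are shown below. What is called first, only, known or untested is meant among the compounds shown, and "the series" means these compounds.

Within the data shown here, only two compounds on this core have readings so far. Among the measured compounds shown here, in a functional assay on MV4-11 cells (Homo sapiens) for antiproliferative activity, read by luminescence and CellTiter-Glo, with a stated time of 72 h (a higher number here means a weaker inhibitor, a lower number a stronger inhibitor), compound 1 (`CNc1cc(-c2ccc3cnn(Cc4ccc(C(F)(F)F)cc4)c3c2)cn(C)c1=O`) gives 4370 nM as its result, and compound 2 (`CCOC(=O)Cn1ncc2ccc(-c3cc(NC)c(=O)n(C)c3)cc21`) gives 8770 nM as its result, so compound 2 stands within the usual scatter of compound 1, the only other measured compound. Compound 3 (`CNc1cc(-c2ccc3cnn(CC4CC4)c3c2)cn(C)c1=O`) has no reading yet. It differs from compound 2 in one group: cyclopropyl in place of ethoxycarbonyl on a saturated chain carbon bound to an aromatic nitrogen.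

For the measured compounds named here, one measured step bears on this place, a 2.0-fold higher number from compound 1 to compound 2 (0.30 log units; within the scatter), and it lies within the scatter. With that single step as the evidence, no step beyond the scatter is expected in this assay for this third group. The expected step is a 1.5-fold lower number from compound 2 to compound 3 (0.16 log units; within the scatter), again within the scatter. Compound 3 is estimated at 6000 nM, with an expected range from 2000 nM to 18000 nM for its reading.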

Compound 3, half-maximal inhibitory concentration: 3450 nM
The estimate for compound 3 lay 1.7-fold (0.24 log units) above the measured number; the range from low to high includes it.
By their numbers in this assay, from the lowest: compounds 3, 1 and 2 (each within the scatter of the next, the first and the last beyond it).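

In this assay this position now shows its first step beyond the scatter, though only a modest one: putting cyclopropyl in place of ethoxycarbonyl gives (a 2.5-fold lower number from compound 2 to compound 3 (0.41 log units; beyond the scatter)). Putting cyclopropyl in place of the much larger 4-(trifluoromethyl)phenyl gives (a 1.3-fold lower number from compound 1 to compound 3 (0.10 log units; within the scatter)), which lies within the scatter, so on this saturated chain carbon these two groups, one with a three-membered ring and one with an aromatic ring, cannot be told apart. Nothing measured here gives a reason for the difference between ethoxycarbonyl and cyclopropyl.

Going by these compounds, it remains open whether a group of another kind on this carbon, such as an amine or a carboxylic acid, would shift the reading further. A longer chain in place of cyclopropyl is equally untested by the compounds shown.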